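Dropping the aryl methyl in a chlorophenoxy thiocarbamate

The source may hold more compounds than are shown below. What is called first, only, known or untested is meant among the compounds shown, and "the series" means these compounds.

Compound 1 `Cc1ccc(NC(=S)OCCNC(=O)C(C)(C)Oc2ccc(Cl)cc2)cc1` was run in an ADME assay on WI-38 cells (Homo sapiens) for cytotoxicity, read by MTT assay, with a stated time of 48 h (on this read-out higher numbers stand for weaker inhibition and lower numbers for stronger inhibition), and in it compound 1 gives > 800000 nM, which is a limit of the assay rather than a number. Compound 2 `CC(C)(Oc1ccc(Cl)cc1)C(=O)Oc1ccc(C(N)=S)cc1` in this assay gives > 800000 nM, also a limit. Compound 3 `O=C(NCCOC(=S)Nc1ccc(F)cc1)c1cccnc1` in this assay gives > 800000 nM, again a limit. Compound 1 therefore stands at the same limit as the other two, and nothing distinguishes the three on these numbers. Compound 4 `CC(C)(Oc1ccc(Cl)cc1)C(=O)NCCOC(=S)Nc1ccccc1` differs from compound 1 by hydrogen in place of methyl on an aromatic carbon. Going by the values given here, because every value so far sits at the limit of > 800000 nM in this assay, at which 3 of the 3 values shown sit, the step expected in this assay is a number no higher from compound 1 to compound 4 (the limit leaves the size open), none beyond the scatter. Compound 4 is accordingly estimated at 800000 nM, with a range from 400000 nM to 1600000 nM, most probably reported again only as a limit.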

Compound 4, half-maximal inhibitory concentration: > 800000 nM
Compound 4 was reported as a limit; the forecaster's own chance of this, stated with the estimate: 85%; the middle value lies on the limit itself.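

Going by these compounds alone, compound 1 and compound 4 both stand only at a limit in this assay, so no step between them can be read: the limit of > 800000 nM in this assay, at which 4 of the 4 values shown sit. On these data alone, whether hydrogen in place of methyl on an aromatic carbon changes the read-out at all remains open.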